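A few compounds are considered here, and "the series" means these few. Any claim that something is new, unique, unknown or untested is made for them only; others in the source may bear on it.

Measured compounds:
- compound 1, `C=CC1=C(C(=O)NCc2ccccc2)C(c2ccc(OC)cc2)OC1`, in a functional assay on HeLa cells (Homo sapiens) for cytotoxicity, read by MTT assay, with a stated time of 24 h (on this read-out higher numbers stand for weaker inhibition and lower numbers for stronger inhibition), gives > 100000 nM, which is a limit of the assay, not a number.
- compound 2, `C=CC1=C(C(=O)O)C(c2ccc(OC)cc2)OC1`, in this assay gives 44300 nM.
- compound 3, `C=CC1=C(C(=O)Nc2ccccc2)C(c2ccc(OC)cc2)OC1`, in this assay gives > 100000 nM, again a limit of the assay rather than a number.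

Compound 1 therefore stands at the limit of this assay, where 2 of the 3 values shown sit (the limit of > 100000 nM in this assay, at which 2 of the 3 values shown sit). Among the measured steps, an at least 2.2-fold lower number from compound 1 to compound 2 (0.35 log units; beyond the scatter) and an at least 2.2-fold higher number from compound 2 to compound 3 (0.35 log units; beyond the scatter) both change the group on the carbonyl carbon, and a step that the two limits leave unreadable from compound 1 to compound 3 cannot be read between the two limits.

Compound 4, `C=CC1=C(C(=O)NCc2ccccc2)C(c2ccc(Cl)c(Cl)c2)OC1`, differs from compound 1 elsewhere: 3,4-dichlorophenyl in place of 4-methoxyphenyl on a saturated ring carbon. For the measured compounds named here, none of the measured steps touches this saturated ring carbon, so no measured step bears on the change directly, and the only anchor is compound 1 sitting at the limit of this assay. The expected step is therefore an at least 1.2-fold lower number from compound 1 to compound 4 (0.09 log units; that floor lies within the scatter), with wide uncertainty. For compound 4 the estimate in this assay is 80000 nM, within a range from 20000 nM to 200000 nM.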

Compound 4, half-maximal inhibitory concentration: > 100000 nM
Compound 4 gave a limit, no number; the forecaster's own chance of this, stated with the estimate: 55%; middle value at least 1.2-fold (0.09 log units) from the limit.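

In this assay compound 4 gives > 100000 nM, which is a limit of the assay and not a number. Compound 1 stands at this same limit, so the step between compound 1 and compound 4 cannot be read: the limit of > 100000 nM in this assay, at which 3 of the 4 values shown sit.

The compounds shown leave open how 3,4-dichlorophenyl and 4-methoxyphenyl compare on the saturated ring carbon of this amide.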